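The source may report more compounds than this note shows. Statements on the series, on what has been measured and on what is new or still open speak of the compounds shown alone.

Measured compounds:
compound 1 `COc1ccc(-c2ccc(OCc3cc(C(=O)NS(=O)(=O)c4ccccc4)oc3C)cc2)cc1` — 5 nM
compound 2 `COc1ccc(-c2ccc(OCc3cc(C(=O)NS(=O)(=O)c4ccccc4)oc3C)cc2)c(C)c1` — 21 nM
compound 3 `CC(=O)c1ccc(-c2ccc(OCc3cc(C(=O)NS(=O)(=O)c4ccccc4)oc3C)cc2)cc1` — 20 nM

In an assay on cells for displacement of a labelled ligand from prostaglandin E2 receptor EP4 subtype (Homo sapiens), read by scintillation counting (a lower number here means a stronger inhibitor, a higher number a weaker inhibitor), compound 3 stands second highest of the three numbers. Its nearest neighbour is compound 2, at 21 nM, and a 1.1-fold lower number from compound 2 to compound 3 (0.02 log units; within the scatter). Its furthest is compound 1, and a 4.0-fold higher number from compound 1 to compound 3 (0.60 log units; beyond the scatter). The other measured step, a 4.2-fold higher number from compound 1 to compound 2 (0.62 log units; beyond the scatter), also concerns the ring bearing methoxy.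

Compound 4 `CC(=O)c1ccc(-c2ccc(OCc3cc(C(=O)O)oc3C)cc2)cc1` differs from compound 3 at the carbonyl carbon: hydroxy in place of (phenylsulfonyl)amino on a carbonyl carbon. Going by the values given here, none of the measured steps touches this carbonyl carbon or the (phenylsulfonyl)amino group; all three concern the ring at the far end of the shared core. No measured step therefore bears on the change from compound 3 to compound 4, and the size of its effect in this assay cannot be read from the numbers shown. For compound 4 a higher number than for compound 3 is expected, with a wide range, and the step of a 3.0-fold higher number from compound 3 to compound 4 (0.48 log units; beyond the scatter) is an estimate only. Compound 4 is estimated at 60 nM, within 10 nM to 400 nM.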

Compound 4, inhibition constant: 150 nM
The estimate for compound 4 lay 2.5-fold (0.40 log units) below the measured number; measured number inside the range.
By their numbers in this assay, from the lowest: compound 1; then compounds 3 and 2 (each within the scatter of the next); then compound 4.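

In this assay, going by these compounds alone, the first change at the carbonyl carbon gives a 7.5-fold higher number from compound 3 to compound 4 (0.88 log units; beyond the scatter), so replacing (phenylsulfonyl)amino with hydroxy raises the number beyond the scatter. The earlier steps shown here all concerned the far end of the shared core, and this result shows that the carbonyl end also affects the number, although compound 4 still gives a measured value of 150 nM without the phenyl ring or the sulfur. No available evidence explains the size of this step.

Going by these compounds, whether the step depends on the phenyl ring or on the sulfonyl amino link remains open, and a (methylsulfonyl)amino group or a plain amino group at the same carbonyl carbon would separate the two. On these data alone, this change has been read only with the acetyl group at the far end, so its size with the methoxy group of compound 1 also remains open.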